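Replacing the benzyl group: expected antiproliferative activity of compound 3

This account rests on a few compounds, and the source may have more. Where it says the series, first, only, none or still open, it means among the compounds named here.

Measured compounds:
compound 1, `CCCCCCCCCCCCCCCCCCNC(=O)[C@H]1CSC(Cc2ccccc2)N1`: 11200 nM
compound 2, `CCCCCCCCCCCCCCCCCCNC(=O)[C@H]1CSC(c2ccc(Br)cc2)N1`: 18300 nM

Of the compounds shown here, two have been tested in a functional assay on TSU-Pr1 cells for antiproliferative activity against TSU (Homo sapiens), read by sulforhodamine B assay; on this read-out higher numbers stand for weaker inhibition and lower numbers for stronger inhibition. Compound 1 gives 11200 nM, and compound 2 gives 18300 nM. On these two numbers compound 1 stands lowest, yet the step of a 1.6-fold higher number from compound 1 to compound 2 (0.21 log units; within the scatter) lies within the scatter, so the two cannot be told apart. The unmeasured compound 3 `CCCCCCCCCCCCCCCCCCNC(=O)[C@H]1CSC(c2ccc(C)cc2)N1` differs from compound 1 by 4-methylphenyl in place of benzyl on a saturated ring carbon. For the measured compounds named here, the only measured step that bears on this change is a 1.6-fold higher number from compound 1 to compound 2 (0.21 log units; within the scatter), which likewise puts an aryl group in place of benzyl on a saturated ring carbon and did not move the number beyond the scatter. A step of about that size, with no direction beyond the scatter, is therefore expected in this assay. Compound 3 is estimated at 14000 nM. For compound 3 the expected range runs from 6000 nM to 35000 nM. This estimate means an expected step of a 1.3-fold higher number from compound 1 to compound 3 (0.10 log units; within the scatter).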

Compound 3, half-maximal inhibitory concentration: 8000 nM
Compound 3: the middle estimate sits 1.8-fold (0.24 log units) above what was measured, and the stated range covers the measured number.
By their numbers in this assay, from the lowest: compounds 3, 1 and 2 (each within the scatter of the next, the first and the last beyond it).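

In this assay, the step of a 1.4-fold lower number from compound 1 to compound 3 (0.15 log units; within the scatter) shows that a second aryl group on this saturated ring carbon, 4-methylphenyl in place of benzyl, again stays within the scatter, so compound 1 and compound 3 cannot be told apart. The earlier compounds shown here could not show a difference between two aryl groups at this carbon, and methyl in place of bromo on an aromatic carbon now gives a modest step beyond the scatter, a 2.3-fold lower number from compound 2 to compound 3 (0.36 log units; beyond the scatter). Nothing measured here accounts for this step.

This single pair does not establish a trend among substituents on the aromatic ring. The compounds shown leave open how an amine or a carboxylic acid in place of the methyl would read, and how a shorter chain on the amide nitrogen would read.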